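The source may report more compounds than this note shows. Statements on the series, on what has been measured and on what is new or still open speak of the compounds shown alone.

Compound 1 `CCCCCCCCCCCC[C@@H](O)[C@H]1CC[C@H]([C@H](O)CCCCCCCCCCNC(=O)c2ccco2)O1`: 100000 nM
Compound 2 `CCCCCCCCCCCC[C@@H](O)[C@H]1CC[C@H]([C@H](O)CCCCCCCCCCNC(=O)c2ccoc2)O1`: 100000 nM
Compound 3 `CCCCCCCCCCCC[C@@H](O)[C@H]1CC[C@H]([C@H](O)CCCCCCCCCCNC(=O)c2cncs2)O1`: 100000 nM

In a functional assay on SK-OV-3 cells (Homo sapiens) for inhibition, read by colorimetric assay and sulforhodamine B assay, with a stated time of 48 h (a higher number here means a weaker inhibitor of growth, a lower number a stronger inhibitor of growth), compound 3 gives 100000 nM, so it stands level with the other two compounds, and none of the three separates from the others. Compound 4 `CCCCCCCCCCCC[C@@H](O)[C@H]1CC[C@H]([C@H](O)CCCCCCCCCCNC(=O)c2ccsc2)O1` keeps the shared core and makes one change: thiophen-3-yl in place of 1,3-thiazol-5-yl on a carbonyl carbon. Within the data shown here, three measured steps bear on this swap, as each exchanges one five-membered aromatic ring for another at that same place: no change at the digits printed from compound 1 to compound 2 (within the scatter), no change at the digits printed from compound 1 to compound 3 (within the scatter) and no change at the digits printed from compound 2 to compound 3 (within the scatter). None of these steps goes beyond the scatter. Thiophen-3-yl itself has not yet been tested in this set, so the expectation rests entirely on these related swaps. The expected result is no change at the digits printed from compound 3 to compound 4 (within the scatter), which means no step beyond the scatter in either direction. For compound 4 the estimated value is 100000 nM, with an expected range from 40000 nM to 120000 nM.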

Compound 4, concentration for 50% growth inhibition: 100000 nM
Compound 4: the middle estimate sits on the measured number at the digits printed; low and high end bracket the measured number.
By their numbers in this assay, from the lowest: compounds 1, 2, 3 and 4 (each within the scatter of the next).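

Removing the ring nitrogen, so that 1,3-thiazol-5-yl becomes thiophen-3-yl, gives no change at the digits printed from compound 3 to compound 4 (within the scatter) in this assay and shows that this nitrogen makes no visible difference on this carbonyl carbon. Sulfur in place of oxygen also leaves the reading flat, with no change at the digits printed from compound 2 to compound 4 (within the scatter) for furan-3-yl and no change at the digits printed from compound 1 to compound 4 (within the scatter) for furan-2-yl as the starting ring. All four five-membered aromatic rings at this place therefore read alike, and no supporting data are available to explain why.

On these data alone, a six-membered ring such as phenyl or pyridinyl at this place remains open, as does a group of another kind, such as an amine or a carboxylic acid. As far as these compounds go, whether any change to the shared core or its long chains would move growth inhibition also remains open.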